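The source may report more compounds than this note shows. Statements on the series, on what has been measured and on what is new or still open speak of the compounds shown alone.

For the measured compounds named here, in a toxicity assay on HEK-293T cells (Homo sapiens) for cytotoxicity, read by MTT assay, with a stated time of 72 h (a higher number here means a weaker inhibitor, a lower number a stronger inhibitor), three compounds sharing one core have numbers so far. Compound 1 `CN(C)CCCCCn1c2c(c3ccccc31)C(=O)c1c[n+]([O-])c3ccccc3c1C2=O` gives 70 nM, compound 2 `CN1CCN(CCCn2c3c(c4ccccc42)C(=O)c2c[n+]([O-])c4ccccc4c2C3=O)CC1` gives 170 nM, and compound 3 `CN(C)CCCCn1c2c(c3ccccc31)C(=O)c1c[n+]([O-])c3ccccc3c1C2=O` gives 520 nM, the highest of the three, with its gaps to both others beyond the scatter. Compound 4 `O=C1c2c[n+]([O-])c3ccccc3c2C(=O)c2c1c1ccccc1n2CCCN1CCC(O)CC1` has not yet been measured. Its difference from compound 3 is 4-hydroxypiperidin-1-yl in place of (dimethylamino)methyl on a saturated chain carbon, three bonds along the chain from an aromatic nitrogen. Going by the values given here, the closest precedent is the step of a 3.1-fold higher number from compound 2 to compound 3 (0.49 log units; beyond the scatter), in which (dimethylamino)methyl takes the place of 4-methylpiperazin-1-yl at that same place. The steps of a 2.4-fold higher number from compound 1 to compound 2 (0.39 log units; beyond the scatter) and a 7.4-fold higher number from compound 1 to compound 3 (0.87 log units; beyond the scatter) are also modest, and they show how far changes in this side chain have moved the number. Read in reverse, the closest precedent points to a modest step towards a lower number in this assay. The expected step is a 2.6-fold lower number from compound 3 to compound 4 (0.41 log units; beyond the scatter). For compound 4 the estimate is 200 nM, with an expected range from 70 nM to 600 nM.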

Compound 4, half-maximal inhibitory concentration: 170 nM
Estimate against measurement, compound 4: 1.2-fold (0.07 log units) above; low and high end bracket the measured number.
By their numbers in this assay, from the lowest: compound 1; then compounds 2 and 4 (each within the scatter of the next); then compound 3.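

In this assay, at this place on a saturated chain carbon, three bonds along the chain from an aromatic nitrogen, a ring-bearing group again separates from the open-chain compound 3: 4-hydroxypiperidin-1-yl gives a 3.1-fold lower number from compound 3 to compound 4 (0.49 log units; beyond the scatter) and so matches the earlier reading with 4-methylpiperazin-1-yl. The comparison of those two rings gives no change at the digits printed from compound 2 to compound 4 (within the scatter) in this assay, so exchanging them leaves the number in place, while the longer-chain compound 1 remains apart, with a 2.4-fold higher number from compound 1 to compound 4 (0.39 log units; beyond the scatter) as the step. Nothing measured here explains these numbers.

Going by these compounds, a plain piperidin-1-yl or a morpholin-4-yl at this place would show whether the hydroxyl group matters apart from the ring, and that remains open. Also open is how 4-hydroxypiperidin-1-yl would read on a longer chain, as the compounds shown do not separate chain length from the choice of amine.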